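The source may hold more compounds than are shown below. What is called first, only, known or untested is meant among the compounds shown, and "the series" means these compounds.

Measured in a functional assay on MCF7 cells (Homo sapiens) for inhibition, read by MTT assay, with a stated time of 48 h; on this read-out higher numbers stand for weaker inhibition and lower numbers for stronger inhibition:
compound 1 `CCOC(=O)C1=C(NN=C(C(C)=O)C(C)=O)Nc2[nH]nc(C)c2C1c1ccc(N(C)C)cc1`: 9740 nM
compound 2 `CCOC(=O)C1=C(N/C=N/c2nnc(S(N)(=O)=O)s2)Nc2[nH]nc(C)c2C1c1ccc(N(C)C)cc1`: 34500 nM
compound 3 `CCOC(=O)C1=C(N/C=N/c2ccccn2)Nc2[nH]nc(C)c2C1c1ccc(N(C)C)cc1`: 37300 nM

Compound 2 stands second highest of these three numbers in this assay. Its nearest neighbour is compound 3, with a 1.1-fold higher number from compound 2 to compound 3 (0.03 log units; within the scatter), which lies within the scatter. Its furthest is compound 1, with a 3.5-fold higher number from compound 1 to compound 2 (0.55 log units; beyond the scatter), which lies beyond the scatter.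

Compound 4 `CCOC(=O)C(=NNC1=C(C(=O)OCC)C(c2ccc(N(C)C)cc2)c2c(C)n[nH]c2N1)C(=O)OCC` has not yet been measured. It departs from compound 2 as follows: a group of 12 heavy atoms (7 carbon, 1 nitrogen, 4 oxygen; no ring) in place of a group of 11 heavy atoms (3 carbon, 4 nitrogen, 2 oxygen, 2 sulfur; one five-membered aromatic ring with 3 hetero atoms), on an amine nitrogen. The five-membered aromatic ring is thus lost, and the entering group, like the group on compound 1, has no ring.

Within the data shown here, two measured steps bear most directly on this change. Each places a ring-bearing group where compound 1 has its ring-free group, and both give higher numbers: a 3.5-fold higher number from compound 1 to compound 2 (0.55 log units; beyond the scatter) and a 3.8-fold higher number from compound 1 to compound 3 (0.58 log units; beyond the scatter). Exchanging one ring-bearing group for the other, in a 1.1-fold higher number from compound 2 to compound 3 (0.03 log units; within the scatter), shows no change beyond the scatter. Read in reverse, these steps point towards a lower number for compound 4. However, no measured compound carries its entering group, so only part of that modest step is assumed.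

The expected change is a 2.5-fold lower number from compound 2 to compound 4 (0.39 log units; beyond the scatter), an estimated modest step towards a lower number. For compound 4 the estimated value is 14000 nM, within an expected range of 5000 nM to 38000 nM.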

Compound 4, half-maximal inhibitory concentration: 89800 nM
Beside the measured number, compound 4's estimate is 6.4-fold (0.81 log units) below it, outside the stated range (above it).
By their numbers in this assay, from the lowest: compound 1; then compounds 2 and 3 (each within the scatter of the next); then compound 4.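

In this assay, removing the ring from this amine nitrogen did not bring the number down, as the ring-free group of 12 heavy atoms gives a 2.6-fold higher number from compound 2 to compound 4 (0.42 log units; beyond the scatter) and a 2.4-fold higher number from compound 3 to compound 4 (0.38 log units; beyond the scatter). The absence of a ring therefore does not by itself set the number at this position: the two ring-free groups mark the two ends of the series, with a 9.2-fold higher number from compound 1 to compound 4 (0.96 log units; beyond the scatter), and the two ring-bearing groups lie between them. Among these compounds, what matters here is which ring-free group is attached, a distinction the earlier compounds, with only one such group, could not reveal. Nothing shown here accounts for the difference between these two ring-free groups.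

The compounds leave open whether the higher number follows the larger count of heavy atoms in the entering group or the particular make-up of that group, since these two ring-free groups differ in both. A ring-free group ending in a carboxylic acid or a primary amide, or one carrying a single acetyl and a single ethyl ester, would help to separate these readings.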